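The source may hold more compounds than are shown below. What is called first, only, known or untested is meant among the compounds shown, and "the series" means these compounds.

Compound 1 `COc1ccc(N(C)c2nc(C)nc3ccccc23)cc1OCCC[Se]C#N` gives 815 nM in a functional assay on MDA-MB-231 cells (Homo sapiens) for inhibition, read by MTT assay, with a stated time of 48 h (a higher number here means a weaker inhibitor, a lower number a stronger inhibitor), far above compound 2 `C[Se]c1ccc(N(C)c2nc(C3CC3)nc3ccccc23)cc1` at 18 nM and within the scatter of compound 3 `COc1ccc(N(C)c2nc(C)nc3ccccc23)cc1C(=O)OCC[Se]C#N` at 1480 nM in the same test. The change leading to compound 4 `COc1ccc(N(C)c2nc(C)nc3ccccc23)cc1OCCCCCC[Se]C#N` is a group of 6 heavy atoms (4 carbon, 1 nitrogen, 1 selenium; no ring) in place of a group of 3 heavy atoms (1 carbon, 1 nitrogen, 1 selenium; no ring), on a saturated chain carbon, three bonds along the chain from an oxygen on an aromatic ring and it brings no ring. Going by the values given here, the one measured step in this side chain is a 1.8-fold higher number from compound 1 to compound 3 (0.26 log units; within the scatter), a change of a different kind. Among the compounds with values here, no measured pair differs only in the way compound 4 differs from compound 1, so no step beyond the scatter is expected in this assay for this change. The expected step is a 1.2-fold lower number from compound 1 to compound 4 (0.07 log units; within the scatter) as an estimate. Compound 4 is estimated at 700 nM, with an expected range from 250 nM to 2000 nM in this test.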

Compound 4, half-maximal inhibitory concentration: 3550 nM
For compound 4 the middle estimate is 5.1-fold (0.71 log units) below the measured one, and the stated range ends below it.
By their numbers in this assay, from the lowest: compound 2; then compounds 1 and 3 (each within the scatter of the next); then compound 4.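

In this assay, the longer chain on the shared core comes at a cost the earlier compounds had not shown: the group of 6 heavy atoms in place of the group of 3 heavy atoms weakens inhibition (a 4.4-fold higher number from compound 1 to compound 4 (0.64 log units; beyond the scatter)). Compound 4 also separates from the carbonyl-bearing chain of compound 3 (a 2.4-fold higher number from compound 3 to compound 4 (0.38 log units; beyond the scatter)), so this side chain does respond to change beyond the scatter. No measured evidence explains this result. Still open, going by these compounds, is whether a chain of intermediate length would fall between compound 1 and compound 4, and whether an amine or a carboxylic acid in place of the selenium-bearing nitrile end would retain activity.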